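Working notes: dimethylamino in place of hydrogen on the aromatic carbon

A few compounds are considered here, and "the series" means these few. Any claim that something is new, unique, unknown or untested is made for them only; others in the source may bear on it.

compound 1 `CC(C)c1ccc(NC(=O)c2csc(Cc3c(Cl)cccc3Cl)n2)cc1`: 370 nM
compound 2 `CC(C)(C)c1ccc(NC(=O)c2csc(Cc3c(Cl)cccc3Cl)n2)cc1`: 570 nM
compound 3 `O=C(Nc1ccccc1)c1csc(Cc2c(Cl)cccc2Cl)n1`: limit, > 4000 nM

In an assay on CHO cells, read by calcium flux (on this read-out higher numbers stand for weaker inhibition and lower numbers for stronger inhibition), compound 1 gives 370 nM and compound 2 gives 570 nM; the step of a 1.5-fold higher number from compound 1 to compound 2 (0.19 log units; within the scatter) stays within the scatter. For compound 3 the assay reports only a limit, > 4000 nM. Compound 3 thus sits at the weak end of the three, at the limit of > 4000 nM in this assay, at which 1 of the 3 values shown sits. The steps of an at least 10-fold higher number from compound 1 to compound 3 (1.03 log units; beyond the scatter) and an at least 7.0-fold higher number from compound 2 to compound 3 (0.84 log units; beyond the scatter) are the only ones that bear on a change at this aromatic carbon, and both were large. Compound 4 `CN(C)c1ccc(NC(=O)c2csc(Cc3c(Cl)cccc3Cl)n2)cc1` differs from compound 3 by dimethylamino in place of hydrogen on an aromatic carbon. Putting a group back at this carbon is expected to lower the number, though dimethylamino is neither isopropyl nor tert-butyl, so a smaller gain is expected. Compound 4 is expected to give about 1500 nM, between 400 nM and 6000 nM, an expected step of an at least 2.6-fold lower number from compound 3 to compound 4 (0.42 log units; beyond the scatter).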

Compound 4, half-maximal inhibitory concentration: > 4000 nM
Compound 4: a limit, no number; the forecaster's own chance of this, stated with the estimate: 30%; middle value at least 2.6-fold (0.42 log units) from the limit.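

Dimethylamino in place of isopropyl gives an at least 10-fold higher number from compound 1 to compound 4 (1.03 log units; beyond the scatter), and dimethylamino in place of tert-butyl gives an at least 7.0-fold higher number from compound 2 to compound 4 (0.84 log units; beyond the scatter). Having a group at this aromatic carbon is therefore not enough in itself: of the groups shown, only isopropyl and tert-butyl give measurable values. Compound 3 and compound 4 are both limits, not numbers, and the step between them cannot be read: the limit of > 4000 nM in this assay, at which 2 of the 4 values shown sit.

As far as these compounds go, whether dimethylamino differs from hydrogen here remains open. Also open, from the compounds shown here alone, is whether other groups at this carbon, such as methoxy, cyclopropyl or a longer chain, would match isopropyl.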